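Replacing an alkyne amide with an azide ketone

The source may report more compounds than this note shows. Statements on the series, on what has been measured and on what is new or still open speak of the compounds shown alone.

Measured compounds:
Compound 1, `CC(=O)Oc1ccc(/C=C/C(=O)O)cc1OC(C)=O` — in an assay on isolated protein for inhibition of Polyunsaturated fatty acid 5-lipoxygenase (Homo sapiens), read by HPLC, with a stated time of 15 min (on this read-out higher numbers stand for weaker inhibition and lower numbers for stronger inhibition), compound 1 gives > 10000 nM, which is a limit of the assay and not a number.
Compound 2, `C#CCCOC(=O)/C=C/c1ccc(OC(C)=O)c(OC(C)=O)c1` — in this assay compound 2 gives > 10000 nM, again a limit.
Compound 3, `C#CCCNC(=O)/C=C/c1ccc(OC(C)=O)c(OC(C)=O)c1` — in this assay compound 3 gives > 10000 nM, also a limit.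

Compound 3 therefore stands at the limit of the assay, and the two further values shown sit at that same limit (the limit of > 10000 nM in this assay, at which 3 of the 3 values shown sit). None of the three measured steps can be read: the change from compound 1 to compound 2 is a step that the two limits leave unreadable from compound 1 to compound 2, from compound 1 to compound 3 it is a step that the two limits leave unreadable from compound 1 to compound 3, and from compound 2 to compound 3 it is a step that the two limits leave unreadable from compound 2 to compound 3.

Compound 4, `CC(=O)Oc1ccc(/C=C/C(=O)CCCN=[N+]=[N-])cc1OC(C)=O`, differs from compound 3 by a group of 6 heavy atoms (3 carbon, 3 nitrogen; no ring) in place of a group of 5 heavy atoms (4 carbon, 1 nitrogen; no ring), on a carbonyl carbon. The measured steps on the shared core all bear on this change only in the sense that every variation of the group on the carbonyl carbon so far has left the value at the limit, so no direction of step can be read from them.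

For compound 4 the expectation is therefore a step that the limit leaves unreadable from compound 3 to compound 4, with the estimated value 15000 nM and a range from 5000 nM to 50000 nM, most probably reported again as a limit.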

Compound 4, half-maximal inhibitory concentration: > 10000 nM
Compound 4: only a limit was reported; the forecaster's own chance of this, stated with the estimate: 80%; the middle value does not contradict the limit.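

No step from compound 1, compound 2 or compound 3 to compound 4 can be read, and none of the four values is a number, only a limit: the limit of > 10000 nM in this assay, at which 4 of the 4 values shown sit.

The compounds shown leave open how strongly each one inhibits the enzyme, and whether changing the group on the carbonyl carbon alters that inhibition at all.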